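A few compounds are considered here, and "the series" means these few. Any claim that something is new, unique, unknown or untested is made for them only; others in the source may bear on it.

In a functional assay on KB cells (Homo sapiens) for cytotoxicity (a higher number here means that more compound is needed for the effect, a lower number that less compound is needed), compound 1 `COC(=O)CC1(O)C=CC(=O)c2ccccc21` gives 20 ug/mL, and compound 2 `COC(=O)CC1(O)C=C(OC)C(=O)c2ccccc21` gives 25 ug/mL. Going by the values given here, these two values lie within the scatter of each other, so compound 2 stands level with the only other measured compound, and no order can be drawn between them. Compound 3 `COC(=O)CC1(O)C=C(C)C(=O)c2ccccc21` is not yet measured. It differs from compound 2 by methyl in place of methoxy on a double-bonded ring carbon, with methyl in place of methoxy on a double-bonded ring carbon. Among the compounds with values here, one measured step bears on this change, since it also swaps the group on a double-bonded ring carbon: a 1.3-fold higher number from compound 1 to compound 2 (0.10 log units; within the scatter). Within the data shown here, with only that small step to go on, no change beyond the scatter is expected in this assay. The expected step is a 1.1-fold lower number from compound 2 to compound 3 (0.06 log units; within the scatter). Compound 3 is estimated at 22 ug/mL, with an expected range from 10 ug/mL to 45 ug/mL.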

Compound 3, concentration for half-maximal effect: 100 ug/mL
Compound 3: middle estimate off by 4.5-fold (0.66 log units), on the low side; measured number outside the range, above it.
By their numbers in this assay, from the lowest: compounds 1 and 2 (each within the scatter of the next); then compound 3.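

In this assay, the group on this double-bonded ring carbon proves able to move the number: methyl in place of methoxy gives a step beyond the scatter (a 4.0-fold higher number from compound 2 to compound 3 (0.60 log units; beyond the scatter)), and methyl in place of hydrogen does the same (a 5.0-fold higher number from compound 1 to compound 3 (0.70 log units; beyond the scatter)). Hydrogen and methoxy had stood level, so the earlier pair alone gave no sign that this position responds at all, and the number does not follow the heavy-atom count of the group, since methyl stands apart from both. Nothing measured here accounts for this result.

The compounds shown leave open whether a longer chain such as ethyl on this carbon would stand with methyl or with hydrogen and methoxy. They also leave open where chlorine or an amine at the same place would fall.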